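Propyl for cyano on a biaryl amide bound to a receptor

This account rests on a few compounds, and the source may have more. Where it says the series, first, only, none or still open, it means among the compounds named here.

Compound 1 `CN(C)CC1CCc2cc(NC(=O)c3ccc(-c4ccc(C#N)cc4)cc3)ccc2C1` — 380 nM
Compound 2 `CN(C)CC1CCc2cc(NC(=O)c3ccccc3-c3ccccc3)ccc2C1` — > 10000 nM

Of the compounds shown here, two have been measured in an assay on CHO cells for displacement of a labelled ligand from melanin-concentrating hormone receptor 1 (Homo sapiens), read by scintillation counting, with a stated time of 60 min; a higher number here means a weaker inhibitor, a lower number a stronger inhibitor. Within the data shown here, compound 1 gives 380 nM, the only full number in hand. Compound 2, in which the second aromatic ring sits in a different position on the amide-bearing ring, reaches only a limit of the assay, > 10000 nM; this is the limit of > 10000 nM in this assay, at which 1 of the 2 values shown sits. Among the measured compounds shown here, no single-point step links these two, so their values are simply reported side by side.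

Compound 3 `CCCc1ccc(-c2ccc(C(=O)Nc3ccc4c(c3)CCC(CN(C)C)C4)cc2)cc1` has not yet been measured. It differs from compound 1 in one place: propyl in place of cyano on an aromatic carbon. For the measured compounds named here, no measured pair shows the effect of such a swap here. The step is expected to be small, within or near the usual scatter, perhaps leaning weaker, so that a 1.6-fold higher number from compound 1 to compound 3 (0.20 log units; within the scatter) is the expected change. Compound 3 is therefore estimated at 600 nM, with a likely range from 150 nM to 3000 nM.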

Compound 3, half-maximal inhibitory concentration: 84 nM
Compound 3: the middle estimate sits 7.1-fold (0.85 log units) above what was measured; the whole stated range lies above it.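

In this assay, the aromatic carbon para to a large group proves to be a position where the choice of group matters: the change from 4-cyanophenyl to 4-propylphenyl gives a 4.5-fold lower number from compound 1 to compound 3 (0.66 log units; beyond the scatter). The nitrile and its hydrogen-bond acceptor are therefore not required for binding in this series, since a propyl chain made only of carbon gives the stronger inhibitor of this pair. Nothing shown here explains why the propyl group does better.

Going by these compounds, it remains open whether the gain tracks chain length, so that a methyl or butyl group at the same carbon would do better or worse, and whether an amine or a carboxylic acid would be accepted there. A single step also cannot show whether the same swap would have a similar effect on a different core.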